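Adding a Methoxy Group to Compound 2

The source may report more compounds than this note shows. Statements on the series, on what has been measured and on what is new or still open speak of the compounds shown alone.

Of the compounds shown here, three have so far been tested in a functional assay on HL-60 cells (Homo sapiens) for cytotoxicity, read by MTT assay, with a stated time of 72 h; on this read-out higher numbers stand for weaker inhibition and lower numbers for stronger inhibition. Compound 1 `Oc1ccc(CC[C@@H](O)C[C@H](O)CCc2ccc(O)c(O)c2)cc1O` gives 1.8 ug/mL in this assay. Compound 2 `OC[C@H]1O[C@@H](O[C@H](CCc2ccc(O)cc2)C[C@H](O)CCc2ccc(O)c(O)c2)[C@H](O)[C@@H](O)[C@@H]1O` gives 5.5 ug/mL, the highest of the two numbers reported, with compound 1 as its nearest neighbour at a lower value that lies beyond the usual scatter. Compound 3 `COc1cc(CC[C@@H](O)C[C@H](O)CCc2ccc(O)cc2)ccc1O` gives only a limit of > 10 ug/mL in this assay, not a number.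

Compound 4 `COc1cc(CC[C@H](C[C@H](O)CCc2ccc(O)c(O)c2)O[C@@H]2O[C@H](CO)[C@@H](O)[C@H](O)[C@H]2O)ccc1O` has not yet been measured. It differs from compound 2 in one place: methoxy in place of hydrogen on an aromatic carbon. Going by the values given here, no measured pair shows this single change on its own, so its size cannot be read directly from the data. Compound 3, which also carries the methoxy group, sits at the limit of > 10 ug/mL in this assay, at which 1 of the 3 values shown sits, and that hints at weaker inhibition, though compound 3 differs from compound 2 in more than this one group. For compound 4 a modest rise in the number, toward weaker inhibition, is expected: a 1.6-fold higher number from compound 2 to compound 4 (0.21 log units; within the scatter). The estimated value for compound 4 is 9 ug/mL, with a range from 4.5 ug/mL to 18 ug/mL.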

Compound 4, half-maximal inhibitory concentration: 4.5 ug/mL
Compound 4: middle estimate off by 2.0-fold (0.30 log units), on the high side; low and high end bracket the measured number.
By their numbers in this assay, from the lowest: compound 1; then compounds 4 and 2 (each within the scatter of the next). At a limit, above all of these: compound 3.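

In this assay, going by these compounds alone, the change can now be read on its own for the first time: methoxy in place of hydrogen on an aromatic carbon, ortho to a hydroxy group, turns 4-hydroxyphenyl into 4-hydroxy-3-methoxyphenyl and gives a 1.2-fold lower number from compound 2 to compound 4 (0.09 log units; within the scatter). On the background of compound 2, this position therefore takes the methoxy group with no shift that stands out from the scatter. Compound 3 also carries the methoxy group but differs from compound 2 in more than this one place, and its entry is a limit and not a number: the limit of > 10 ug/mL in this assay, at which 1 of the 4 values shown sits.

One pair cannot say whether the same holds on other backgrounds, such as the core of compound 1. Going by these compounds, how an ethoxy group, a chlorine atom or an amine would read at this position also stays open.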